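A few compounds are considered here, and "the series" means these few. Any claim that something is new, unique, unknown or untested is made for them only; others in the source may bear on it.

In a physicochemical assay (a lower number here means that less compound is needed, a higher number that more compound is needed for the effect), compound 1 `COc1cc(/C=N/NC(=O)c2nn(-c3ccnc4cc(Cl)ccc34)c(-c3ccc(Cl)cc3)c2C)ccc1O` gives 4590000 nM and compound 2 `COc1cc(/C=N/NC(=O)c2nn(-c3ccc(F)c(Cl)c3)c(-c3ccc(F)cc3)c2C)ccc1O` gives 6920000 nM as the half-maximal effective concentration. For the measured compounds named here, these two values lie within the scatter of each other, so compound 2 stands level with compound 1 on the only numbers available, although the two differ at more than one place on the shared core.

Compound 3 `COc1cc(/C=N/NC(=O)c2nn(-c3ccnc4cc(Cl)ccc34)c(-c3ccc(F)cc3)c2C)ccc1O` has not yet been measured. It departs from compound 2 in one place, with 7-chloroquinolin-4-yl in place of 3-chloro-4-fluorophenyl on an aromatic nitrogen (difference: 7-chloroquinolin-4-yl in place of 3-chloro-4-fluorophenyl on an aromatic nitrogen). The entering group lies next to the ring atom that bears a 4-fluorophenyl group, which stays.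

Going by the values given here, no measured pair isolates this change. The nearest evidence is compound 1 at 4590000 nM with 7-chloroquinolin-4-yl on that nitrogen, though without the 4-fluorophenyl group. No step beyond the scatter is therefore expected in this assay for this change. The estimated step of a 1.3-fold lower number from compound 2 to compound 3 (0.12 log units; within the scatter) is expected to stay within the scatter. For compound 3 the expected value is 5200000 nM (estimated range 2500000 nM to 10500000 nM).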

Compound 3, half-maximal effective concentration: 6450000 nM
The estimate for compound 3 lay 1.2-fold (0.09 log units) below the measured number; the measured number falls inside the stated range.
By their numbers in this assay, from the lowest: compounds 1, 3 and 2 (each within the scatter of the next).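

For the compounds shown here, the pair of compound 2 and compound 3 isolates the exchange on the aromatic nitrogen for the first time: in this assay, 7-chloroquinolin-4-yl in place of 3-chloro-4-fluorophenyl gives a 1.1-fold lower number from compound 2 to compound 3 (0.03 log units; within the scatter) with the 4-fluorophenyl group held constant, so swapping a single carbon-only aromatic ring for the two-ring group, which brings a ring nitrogen and one hydrogen-bond acceptor, leaves the number level within the scatter. Compound 3 also opens a second single-place comparison, which compound 1 and compound 2 could not provide: with 7-chloroquinolin-4-yl held constant, fluoro in place of chloro on an aromatic carbon gives a 1.4-fold higher number from compound 1 to compound 3 (0.15 log units; within the scatter) and this step too stays within the scatter. Neither exchange therefore separates these compounds in this assay, and nothing available explains why these numbers stay level.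

As far as these compounds go, all three compounds carry a large aromatic group on that nitrogen, so it remains open whether a group of another kind there, such as a short alkyl chain, an amine or a carboxylic acid, would stay level as well. The same question stands for the halogen, since a methoxy group or a nitrile in its place could give a step beyond the scatter or none.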